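Swapping fluoro for hydroxy on the benzylidene ring

A few compounds are considered here, and "the series" means these few. Any claim that something is new, unique, unknown or untested is made for them only; others in the source may bear on it.

Measured compounds:
compound 1 `O=C(N/N=C/c1ccccc1)c1cnccn1`, 75%
compound 2 `O=C(N/N=C/c1ccccc1F)c1cnccn1`, 100%
compound 3 `O=C(N/N=C/c1ccc(Br)cc1)c1cnccn1`, 100%

In an ADME assay on J774 cells (Mus musculus) for cytotoxicity, read by MTT assay, with a stated time of 48 h, tested at 100 ug/mL (on this read-out higher numbers stand for a weaker effect at the one concentration tested and lower numbers for a stronger effect), compound 1 gives 75%. Compound 2 gives 100% in this assay, and compound 3 gives 100%. Compound 2 thus stands level with compound 3 at the digits shown, the two together the highest of the three numbers, while compound 1 sits lower.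

The step that follows leads to compound 4 `O=C(N/N=C/c1ccccc1O)c1cnccn1`, not yet measured in this assay. The change from compound 2 is hydroxy in place of fluoro on an aromatic carbon.

Within the data shown here, no measured step exchanges one substituent for another; the two known steps each add a group where a hydrogen stood. The step of a number 25 percentage points higher from compound 1 to compound 2 (beyond the scatter) and the step of a number 25 percentage points higher from compound 1 to compound 3 (beyond the scatter) both raised the number by the same modest amount. Those steps bear only indirectly here, since the aromatic carbon stays substituted in compound 4. A small downward step or none beyond the scatter is therefore expected.

For compound 4 the expected value is 90%, with a range from 70% to 100%. This estimate means a step of a number 10 percentage points lower from compound 2 to compound 4 (within the scatter) is expected.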

Compound 4, a percentage reported as activity, at one concentration (the size of the read-out at that concentration, not a potency): 0.3%
Compound 4: the middle estimate sits 89.7 percentage points above what was measured; measured number below the stated range.
By their numbers in this assay, from the lowest: compound 4; then compound 1; then compounds 2 and 3 (each within the scatter of the next).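

The exchange of fluoro for hydroxy gives a number 99.7 percentage points lower from compound 2 to compound 4 (beyond the scatter) in this assay, so this carbon, ortho to a large group, is highly sensitive to which single atom is attached, and a lower number here means a stronger effect at the one concentration tested. Hydroxy in place of hydrogen gives a number 74.7 percentage points lower from compound 1 to compound 4 (beyond the scatter) while fluoro in place of hydrogen gives a number 25 percentage points higher from compound 1 to compound 2 (beyond the scatter) and so, at this carbon, the two groups move the number in opposite directions from the unsubstituted compound. No measurement available here accounts for so large a difference.

The compounds shown leave open whether the strong effect is particular to hydroxy or would also appear with an amine or a methoxy group at this carbon. They also leave open whether hydroxy would act the same way on another carbon of the ring.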